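A Pyrrole Replaces the Methoxyphenyl Arm

The source may report more compounds than this note shows. Statements on the series, on what has been measured and on what is new or still open speak of the compounds shown alone.

Compound 1 `Cc1ccc(-c2cc(Cl)ccc2CCCCCC[C@@H](O)C[C@](O)(CC(=O)O)C(=O)O)cc1` gives 2700 nM in an assay on isolated protein for inhibition of ATP-citrate synthase (Homo sapiens); a higher number here means a weaker inhibitor, a lower number a stronger inhibitor. Compound 2 `COc1ccc(-c2cc(Cl)ccc2CCCCCC[C@@H](O)C[C@](O)(CC(=O)O)C(=O)O)cc1` gives 5100 nM in this assay, and among the two measured numbers it sits alongside compound 1, the pair within the scatter of each other, as a 1.9-fold higher number from compound 1 to compound 2 (0.28 log units; within the scatter) shows. Compound 3 `O=C(O)C[C@@](O)(C[C@H](O)CCCCCCc1ccc(Cl)cc1-n1cccc1)C(=O)O` differs from compound 2 by 1H-pyrrol-1-yl in place of 4-methoxyphenyl on an aromatic carbon. Within the data shown here, only the step from compound 1 to compound 2 bears on this, and it lay within the scatter, so little guidance exists for so large an exchange. Compound 3 is therefore expected to give about 8000 nM, between 2500 nM and 25000 nM, a step of a 1.6-fold higher number from compound 2 to compound 3 (0.20 log units; within the scatter) that is estimated, not measured.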

Compound 3, inhibition constant: 3900 nM
Beside the measured number, compound 3's estimate is 2.1-fold (0.31 log units) above it; low and high end bracket the measured number.
By their numbers in this assay, from the lowest: compounds 1, 3 and 2 (each within the scatter of the next).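

In this assay, the 1H-pyrrol-1-yl group, a five-membered aromatic ring with 1 hetero atom, stands at this place in compound 3 with no step beyond the scatter from either six-membered arm: a 1.3-fold lower number from compound 2 to compound 3 (0.12 log units; within the scatter) and a 1.4-fold higher number from compound 1 to compound 3 (0.16 log units; within the scatter). Across these three compounds, this place therefore tolerates 5 heavy atoms as well as 8 in the group, though nothing shown explains why the numbers stay so close.

Still open, from the compounds shown here alone, is how this assay would read with an amine, a carboxylic acid or a pyridine ring at this place. The compounds shown also leave open whether any group here could move the number beyond the scatter.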